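The source may hold more compounds than are shown below. What is called first, only, known or untested is meant among the compounds shown, and "the series" means these compounds.

Measured compounds in an assay on Sf9 cells for inhibition of protein deacetylase HDAC6 (Homo sapiens), read by fluorescence, with a stated time of 40 min, tested at 100 nM; a higher number here means more inhibition at the concentration tested (going by the name of the read-out), a lower number less inhibition:
compound 1 `O=C(NO)c1ccc(NCc2nc(-c3cccs3)nn2-c2ccc(O)cc2)cc1` — 79.6%
compound 2 `O=C(NO)c1ccc(NCc2nc(-c3ccc(Br)cc3)nn2-c2ccccc2)cc1` — 54.7%
compound 3 `CNC(=O)c1ccc(NCc2nc(-c3ccccc3)nn2-c2ccccc2)cc1` — -3.6%

Of the three numbers, compound 2 stands second highest in this assay. Within the data shown here, compound 1 sits higher, beyond the scatter, and compound 3 sits lower, again beyond the scatter; no single-point step between any of these pairs is available, so only the values themselves are compared here.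

Compound 4 `O=C(NO)c1ccc(NCc2nc(-c3ccsc3)nn2-c2ccccc2)cc1` is not yet measured. Relative to compound 2 the change is thiophen-3-yl in place of 4-bromophenyl on an aromatic carbon. Among the measured compounds shown here, no measured pair shows this exact step, so its size has to be estimated from the range already seen. Compound 1, which carries a thiophene ring at the same position along with a different phenyl substituent, gives 79.6%, and compound 2 gives 54.7%; the step expected from compound 2 to compound 4 is therefore small and upward, a number 7.3 percentage points higher from compound 2 to compound 4 (within the scatter), though it may well fall within the scatter. For compound 4 the estimate in this assay is 62%, with a range of 42% to 80%.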

Compound 4, a percentage reported as inhibition, at one concentration (the size of the read-out at that concentration, not a potency): 53.4%
Beside the measured number, compound 4's estimate is 8.6 percentage points above it, and the stated range covers the measured number.
By their numbers in this assay, from the lowest: compound 3; then compounds 4 and 2 (each within the scatter of the next); then compound 1.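

In this assay, among these compounds, the first single-place step at this aromatic carbon of the five-membered ring is a number 1.3 percentage points lower from compound 2 to compound 4 (within the scatter). For this pair, the read-out at the one tested concentration does not separate thiophen-3-yl from 4-bromophenyl, so neither the bromine nor the six-membered ring is needed to hold inhibition at this level. Nothing available gives a reason for this result.

Among the compounds shown here, compound 1 differs from compound 4 in more than one place, so no step between them can be read, and the separate contributions of its two differences stay unknown. Also open, from the compounds shown here alone, is whether the inhibition in this assay would be higher, lower or level with a group of another kind at this position, such as an amine, a carboxylic acid or a longer alkyl chain, in place of an aromatic ring.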